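This account rests on a few compounds, and the source may have more. Where it says the series, first, only, none or still open, it means among the compounds named here.

Compound 1 `CCCNc1nc(NCc2ccc(NC(=O)c3ccc(F)cc3)cc2)c2ccccc2n1` gives 2000 nM in a functional assay on SW480 cells (Homo sapiens) for inhibition, read by luminescence and resazurin assay, with a stated time of 3 days; on this read-out lower numbers stand for stronger inhibition and higher numbers for weaker inhibition.
Compound 2 `CCNc1nc(NCc2ccc(NC(=O)c3ccc(F)cc3)cc2)c2ccccc2n1` gives 2300 nM in this assay.
Compound 3 `CCCNc1nc(NCc2ccc(C(=O)Nc3ccc(F)cc3)cc2)c2ccccc2n1` gives 1600 nM in this assay.

The change from compound 2 to compound 1 is methyl in place of hydrogen on a saturated chain carbon, two bonds along the chain from a nitrogen on an aromatic ring, and it made a 1.2-fold lower number from compound 2 to compound 1 (0.06 log units; within the scatter). The further step was a 1.3-fold lower number from compound 1 to compound 3 (0.10 log units; within the scatter). How the cores of compound 2 and compound 3 differ is not broken down here. Compound 4 `CCCCNc1nc(NCc2ccc(C(=O)Nc3ccc(F)cc3)cc2)c2ccccc2n1` has not yet been measured in this assay; it differs from compound 3 by methyl in place of hydrogen on a saturated chain carbon, three bonds along the chain from a nitrogen on an aromatic ring. The surroundings are not identical: in the earlier change the carbon lies two bonds along the chain from a nitrogen on an aromatic ring, here three bonds along, so this is the same kind of change rather than the same one. Because the earlier step was a 1.2-fold lower number from compound 2 to compound 1 (0.06 log units; within the scatter), compound 4 is expected to show a 1.1-fold lower number from compound 3 to compound 4 (0.06 log units; within the scatter). For compound 4 the estimate in this assay is 1400 nM, between 700 nM and 2800 nM.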

Compound 4, half-maximal inhibitory concentration: 1000 nM
Compound 4: middle estimate off by 1.4-fold (0.15 log units), on the high side, and the stated range covers the measured number.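

In this assay, methyl in place of hydrogen on the chain gave a 1.6-fold lower number from compound 3 to compound 4 (0.20 log units; within the scatter). Set beside the earlier step, the two steps agree: the same change on two cores in this assay, a 1.2-fold lower number (0.06 log units; within the scatter) from compound 2 to compound 1 and a 1.6-fold lower number (0.20 log units; within the scatter) from compound 3 to compound 4, 1.4-fold (0.14 log units) apart, within the scatter of two such steps. The change therefore read alike on these two cores, but neither step stands clear of the scatter, so this shows agreement between two small steps, not that the change strengthens inhibition on either core, and it says nothing about other cores.

The compounds shown leave open how a chain longer than butyl, a branched chain or a chain carrying an amine would read. They also leave open whether the change would carry over to a core with chlorine in place of fluorine.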